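The source may report more compounds than this note shows. Statements on the series, on what has been measured and on what is new or still open speak of the compounds shown alone.

For the measured compounds named here, in a physicochemical assay for solubility, using the shake flask method, in phosphate buffer, with a stated time of 24 h, at pH 7.4 (on this read-out lower numbers stand for lower solubility and higher numbers for higher solubility), compound 3 `CC(Sc1nc2nn(C3COC3)cc2c(=O)n1-c1ccccc1)c1cccnc1` gives 189000 nM, the highest of the three numbers measured so far. The lower numbers belong to compound 1 `CC(Sc1nc2nn(CC3COC3)cc2c(=O)n1-c1ccccc1)c1ccccc1`, at 77000 nM, and compound 2 `CC(Sc1nc2nn(C3COC3)cc2c(=O)n1-c1ccccc1)c1ccccn1`, at 60000 nM. The next structure, compound 4 `CC(Sc1nc2nn(C3COC3)cc2c(=O)n1-c1ccccc1)c1ccccc1`, has phenyl in place of pyridin-3-yl on a saturated chain carbon bound to a saturated chain carbon and a sulfur. Going by the values given here, the only measured step at this place is a 3.2-fold higher number from compound 2 to compound 3 (0.50 log units; beyond the scatter), with pyridin-3-yl in place of pyridin-2-yl, so changing this ring alone has already moved the number by a modest amount. Among the compounds with values here, no measured step swaps pyridin-3-yl directly for phenyl. Compound 1 also carries phenyl at this place but differs elsewhere, and its 77000 nM is lower than the number for compound 3. A modest fall of similar size is therefore expected in this assay, and the expected step is a 3.2-fold lower number from compound 3 to compound 4 (0.50 log units; beyond the scatter). The estimate for compound 4 is 60000 nM, with an expected range of 22000 nM to 130000 nM.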

Compound 4, solubility: 26000 nM
Estimate against measurement, compound 4: 2.3-fold (0.36 log units) above, and the stated range covers the measured number.
By their numbers in this assay, from the lowest: compound 4; then compounds 2 and 1 (each within the scatter of the next); then compound 3.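

In this assay the direct exchange of pyridin-3-yl for phenyl gives a 7.3-fold lower number from compound 3 to compound 4 (0.86 log units; beyond the scatter) and the exchange of pyridin-2-yl for phenyl gives a 2.3-fold lower number from compound 2 to compound 4 (0.36 log units; beyond the scatter), so among these three compounds, which differ only at this place, phenyl gives the lowest number and either pyridinyl ring a higher one. The other place matters as well: with phenyl kept, the change on the aromatic nitrogen gives a 3.0-fold lower number from compound 1 to compound 4 (0.47 log units; beyond the scatter). Nothing measured here accounts for these differences.

Still open, going by these compounds, is whether pyridin-3-yl would keep its lead over phenyl with (oxetan-3-yl)methyl on the aromatic nitrogen. Also open, on these data alone, is how the number would respond to an amine or a carboxylic acid on the phenyl ring.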